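Pentyl Replaces 2-Fluorophenyl on the Triazole Carbon

The source may report more compounds than this note shows. Statements on the series, on what has been measured and on what is new or still open speak of the compounds shown alone.

Measured compounds:
compound 1 `CCCCc1cn(C(c2ccccc2)c2cc3cc(Br)ccc3nc2OC)nn1`: 5.46%
compound 2 `COc1nc2ccc(Br)cc2cc1C(c1ccccc1)n1cc(-c2ccccc2F)nn1`: 14.7%

Of the compounds shown here, two have been measured in an ADME assay on PANC-1 cells (Homo sapiens) for cytotoxicity, read by sulforhodamine B assay, with a stated time of 48 h, tested at 10 uM; a lower number here means less inhibition, a higher number more inhibition at the concentration tested (going by the name of the read-out). Compound 1 `CCCCc1cn(C(c2ccccc2)c2cc3cc(Br)ccc3nc2OC)nn1` gives 5.46%, and compound 2 `COc1nc2ccc(Br)cc2cc1C(c1ccccc1)n1cc(-c2ccccc2F)nn1` gives 14.7%. For the measured compounds named here, compound 2 sits at the end of the only measured step, a number 9.2 percentage points higher from compound 1 to compound 2 (within the scatter), and since that step lies within the usual scatter, the numbers of compound 2 and compound 1 cannot be told apart.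

Compound 3 `CCCCCc1cn(C(c2ccccc2)c2cc3cc(Br)ccc3nc2OC)nn1` is not yet measured. It differs from compound 2 by pentyl in place of 2-fluorophenyl on an aromatic carbon. Going by the values given here, the one step that bears on this change is a number 9.2 percentage points higher from compound 1 to compound 2 (within the scatter), in which a 2-fluorophenyl group replaced an alkyl chain; the present change runs the other way, putting an alkyl chain back in place of the 2-fluorophenyl group, with pentyl rather than butyl. As that earlier step was within the scatter, no step beyond the scatter is expected here either, and the number is expected to land near that of compound 1. The expected step is a number 7.7 percentage points lower from compound 2 to compound 3 (within the scatter). For compound 3 the estimate is 7%, between 0% and 18%.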

Compound 3, a percentage reported as inhibition, at one concentration (the size of the read-out at that concentration, not a potency): 5.07%
Beside the measured number, compound 3's estimate is 1.9 percentage points above it; the range from low to high includes it.
By their numbers in this assay, from the lowest: compounds 3, 1 and 2 (each within the scatter of the next).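

Putting pentyl in place of 2-fluorophenyl on this aromatic carbon gives a number 9.6 percentage points lower from compound 2 to compound 3 (within the scatter) in this assay and shows that, with a different alkyl chain as well, exchanging the aryl group for a chain leaves the number within the scatter. Methyl in place of hydrogen on a saturated chain carbon, four bonds along the chain from an aromatic carbon, gives a number 0.4 percentage points lower from compound 1 to compound 3 (within the scatter) and adds that butyl and pentyl cannot be told apart at this position, so all three groups now shown here stay within the scatter of one another. No outside evidence bears on these numbers.

The compounds shown leave open whether any group on this carbon can move the number beyond the scatter, for example a chain ending in an amine or a carboxylic acid, or a much longer chain such as decyl. They also leave open whether plain phenyl would read differently from 2-fluorophenyl, and whether changes elsewhere on the shared core would matter more than changes at this position.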